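A few compounds are considered here, and "the series" means these few. Any claim that something is new, unique, unknown or untested is made for them only; others in the source may bear on it.

In a functional assay on PC-3 cells (Homo sapiens), read by MTT assay, with a stated time of 48 h (a higher number here means a weaker inhibitor, a lower number a stronger inhibitor), compound 1 `CCn1c(C(=O)NCCN)ccc1C(CC)(CC)c1ccc(OCC(=O)C(C)(C)C)c(C)c1` gives 480 nM, compound 2 `CCN(CC)CCNC(=O)c1ccc(C(CC)(CC)c2ccc(OCC(O)C(C)(C)C)c(C)c2)n1CC` gives 220 nM, and compound 3 `C#CCNC(=O)c1ccc(C(CC)(CC)c2ccc(OCC(O)C(C)(C)C)c(C)c2)n1CC` gives 16200 nM, the highest of the three numbers. Compound 4 `C=CCN(C)C(=O)c1ccc(C(CC)(CC)c2ccc(OCC(O)C(C)(C)C)c(C)c2)n1CC`, not yet measured, differs from compound 3 by allyl(methyl)amino in place of propargylamino on a carbonyl carbon, with allyl(methyl)amino in place of propargylamino on a carbonyl carbon. Within the data shown here, the one measured step bearing on this is a 74-fold higher number from compound 2 to compound 3 (1.87 log units; beyond the scatter), a large one, with ethynyl in place of (diethylamino)methyl. Neither side of the present change carries that diethylamino group, so a step of that size is not expected here. The expected change in this assay is a 1.4-fold lower number from compound 3 to compound 4 (0.13 log units; within the scatter), which stays within the scatter. For compound 4 the estimated value is 12000 nM, with an expected range of 4000 nM to 35000 nM.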

Compound 4, half-maximal inhibitory concentration: 25900 nM
Estimate against measurement, compound 4: 2.2-fold (0.33 log units) below, within the range that was stated.
By their numbers in this assay, from the lowest: compound 2; then compound 1; then compounds 3 and 4 (each within the scatter of the next).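

In this assay, replacing propargylamino with allyl(methyl)amino on the carbonyl carbon gives a 1.6-fold higher number from compound 3 to compound 4 (0.20 log units; within the scatter), so removing the amide hydrogen and exchanging the triple bond for a double bond leaves the number within the scatter. The wider step, a 120-fold higher number from compound 2 to compound 4 (2.07 log units; beyond the scatter), shows that a second side chain without the (2-(diethylamino)ethyl)amino group also stands far from compound 2. No available evidence explains either step. The compounds shown leave open whether a morpholine or a carboxylic acid at the end of the ethyl chain would keep the number of compound 2.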